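The source may report more compounds than this note shows. Statements on the series, on what has been measured and on what is new or still open speak of the compounds shown alone.

Three compounds have so far been run in a functional assay on the whole organism with Mus musculus as the target, at a dose of 100 mg/kg by the intraperitoneal route; a higher number here means more inhibition at the dose given (going by the name of the read-out), a lower number less inhibition. Compound 1 `O=C(/C=C1\CCc2cc(F)cc(F)c21)NC1CC1` gives 100% in this assay. Compound 3 `O=C(/C=C1\CCc2c(F)cc(F)cc21)NC1CC1` gives 100%, and compound 2 `CNC(=O)/C=C1\CCc2c(F)cc(F)cc21` gives 100%, so the three stand level within the scatter. The difference between the cores of compound 1 and compound 3 is not broken down here. From compound 3 to compound 2 the change is methyl in place of cyclopropyl on an amide-type nitrogen, and the step is no change at the digits printed from compound 3 to compound 2 (within the scatter). Compound 4 `CNC(=O)/C=C1\CCc2cc(F)cc(F)c21` remains unmeasured; it differs from compound 1 by methyl in place of cyclopropyl on an amide-type nitrogen, the same change carried onto the core of compound 1. Because the earlier step was no change at the digits printed from compound 3 to compound 2 (within the scatter), the step from compound 1 to compound 4 is expected to be no change at the digits printed from compound 1 to compound 4 (within the scatter). Compound 4 is therefore estimated to give 100% in this assay, likely between 85% and 100%.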

Compound 4, a percentage reported as inhibition, in the whole organism at one dose (the size of the read-out at that dose, not a potency): 33%
Compound 4: middle estimate off by 67 percentage points, on the high side; the whole stated range lies above it.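

Methyl in place of cyclopropyl on an amide-type nitrogen gave a number 67 percentage points lower from compound 1 to compound 4 (beyond the scatter), so the result on one core did not hold on the other. In this assay this change therefore cannot be carried between these cores as a fixed step: the same change on two cores in this assay, no change at the digits printed (within the scatter) from compound 3 to compound 2 and a number 67 percentage points lower (beyond the scatter) from compound 1 to compound 4, 67 percentage points apart, beyond the scatter of two such steps This shows that the outcome of the change depends on the core, but it rests on a single pair of cores at one dose and does not show which feature of the core matters or how the change would behave on a further core.

The compounds shown carry only cyclopropyl and methyl on that nitrogen, so ethyl, isopropyl and cyclobutyl on either core remain open. Also open, as far as these compounds go, is whether compound 1, compound 2 and compound 3 would separate at a lower dose.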